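The compounds below may be only part of what the source reports. "The series", "measured", "known", "first", "only" and "open" are said of these compounds alone.

Measured so far:
Compound 1, `O=c1ccoc2cc(OCc3cn(Cc4cccc(F)c4)nn3)ccc12`: > 100000 nM
Compound 2, `Cc1ccccc1Cn1cc(COc2ccc3c(=O)ccoc3c2)nn1`: > 100000 nM
Compound 3, `O=c1ccoc2cc(OCc3cn(Cc4cccc(Cl)c4)nn3)ccc12`: 28400 nM

Going by the values given here, in a functional assay on QGY7701 cells (Homo sapiens) for cytotoxicity, read by MTT assay, with a stated time of 48 h (a higher number here means a weaker inhibitor, a lower number a stronger inhibitor), compound 3 gives the only number in the set, 28400 nM. For compound 1 the value > 100000 nM is a limit of the assay, not a number. For compound 2 the value > 100000 nM is likewise a limit. Among the compounds with values here, two of the three values sit at the limit of > 100000 nM in this assay, at which 2 of the 3 values shown sit, so only the steps into compound 3 can be read: an at least 3.5-fold lower number from compound 1 to compound 3 (0.54 log units; beyond the scatter) with chloro in place of fluoro on an aromatic carbon, and an at least 3.5-fold lower number from compound 2 to compound 3 (0.54 log units; beyond the scatter) with 3-chlorophenyl in place of 2-methylphenyl on a saturated chain carbon bound to an aromatic nitrogen. The step from compound 1 to compound 2 cannot be read from two limits.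

Compound 4, `O=c1ccoc2cc(OCc3cn(Cc4ccc(Br)cc4)nn3)ccc12`, is not yet measured. Its change from compound 3 is 4-bromophenyl in place of 3-chlorophenyl on a saturated chain carbon bound to an aromatic nitrogen. Within the data shown here, the two readable steps show that the group on this phenyl ring moves the number at least modestly, but bromo in place of chloro has no direct precedent among the measured compounds, and the halogen is retained. The expectation is that compound 4 stays near compound 3, with a 1.1-fold lower number from compound 3 to compound 4 (0.06 log units; within the scatter) as the estimated step. Compound 4 is therefore expected at 25000 nM, with a range from 8000 nM to 90000 nM.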

Compound 4, half-maximal inhibitory concentration: 96400 nM
The estimate for compound 4 lay 3.9-fold (0.59 log units) below the measured number, outside the stated range (above it).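

In this assay, a 3.4-fold higher number from compound 3 to compound 4 (0.53 log units; beyond the scatter), so keeping a halogen on the phenyl ring does not by itself preserve the number of compound 3, and the change from 3-chlorobenzyl to 4-bromobenzyl matters at this position, on a saturated chain carbon bound to an aromatic nitrogen. Compound 4 gives a second true number in the series, but its comparisons with the two limit compounds show almost nothing: an at least 1.0-fold lower number from compound 2 to compound 4 (0.01 log units; that floor lies within the scatter), and an at least 1.0-fold lower number from compound 1 to compound 4 (0.01 log units; that floor lies within the scatter). These two steps stay open-ended, and compound 3 remains the strongest of the four, because the values of compound 1 and compound 2 are limits and not numbers: the limit of > 100000 nM in this assay, at which 2 of the 4 values shown sit.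

The step from compound 3 to compound 4 changes the halogen and its place on the phenyl ring together, and no compound shown separates the two, such as one with bromo where the 3-chlorophenyl group carries chloro. Also open, from the compounds shown here alone, is how this position responds to anything other than a halogen or methyl on the phenyl ring, such as an amine or a carboxylic acid, or to a longer chain in place of the benzyl link.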